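Cytotoxicity notes on an aryl amide series with hexanoate chains

A few compounds are considered here, and "the series" means these few. Any claim that something is new, unique, unknown or untested is made for them only; others in the source may bear on it.

Compound 1 `CC(C)N(Cc1cccc(OCCCCCC(=O)O)c1)C(=O)c1ccc(-c2cccc(Oc3ccccc3)c2)cc1` is the reference. In an ADME assay on BJ cells (Homo sapiens) for cytotoxicity, read by CellTiter-Glo and resazurin assay, with a stated time of 72 h (on this read-out lower numbers stand for an effect already at smaller amounts and higher numbers for an effect only at larger amounts of compound), compound 1 gives only a limit, > 18700 nM. Compound 2 `CC(C)N(Cc1cccc(OCCCCCC(=O)O)c1)C(=O)c1ccc(-c2cccc(OCc3ccccc3)c2)cc1` differs by benzyl in place of phenyl on an oxygen on an aromatic ring. In this assay compound 2 likewise returns a limit, > 26000 nM. The step that the two limits leave unreadable from compound 1 to compound 2 therefore cannot be sized. Compound 1 sits at the limit of > 18700 nM in this assay, at which 1 of the 3 values shown sits. Compound 2 sits at the limit of > 26000 nM in this assay, at which 1 of the 3 values shown sits.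

Compound 3 `CCOC(=O)CCCCCOc1cccc(CN(C(=O)c2ccc(-c3cccc(Oc4ccccc4)c3)cc2)C(C)C)c1` carries the other core; the two cores differ by ethyl in place of hydrogen on an oxygen next to a carbonyl group. In this assay compound 3 also gives a limit, > 19600 nM. The step that the two limits leave unreadable from compound 1 to compound 3 is equally unreadable. Compound 3 sits at the limit of > 19600 nM in this assay, at which 1 of the 3 values shown sits.

Compound 4 `CCOC(=O)CCCCCOc1cccc(CN(C(=O)c2ccc(-c3cccc(OCc4ccccc4)c3)cc2)C(C)C)c1` is not yet measured. It differs from compound 3 by benzyl in place of phenyl on an oxygen on an aromatic ring, the same change as that from compound 1 to compound 2, at a place described in the same words. Since all three measured compounds sit at limits, no readable step is available to transfer; the expectation is that compound 4 stays without a measurable effect, with an expected step that the limit leaves unreadable from compound 3 to compound 4 that cannot be confirmed from the data. Compound 4 is estimated at 30000 nM in this assay, between 15000 nM and 90000 nM.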

Compound 4, half-maximal effective concentration: > 26000 nM
Compound 4: only a limit was reported; the forecaster's own chance of this, stated with the estimate: 85%; the middle value lies beyond the limit too.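

In this assay compound 4 gives > 26000 nM, again a limit, so the steps to compound 4 from compound 3 and from compound 2 cannot be read. On these data alone, with all four compounds at limits, what remains open is whether any of them reaches a half-maximal effect on these cells, and whether benzyl in place of phenyl or ethyl in place of hydrogen changes it.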